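This account rests on a few compounds, and the source may have more. Where it says the series, first, only, none or still open, it means among the compounds named here.

In an ADME assay on the whole organism for pharmacokinetics, with Rattus norvegicus as the target, with a stated time of 6 h, at a dose of 10 mg/kg by the oral route (on this read-out lower numbers stand for lower exposure and higher numbers for higher exposure at the dose given), compound 3 `Cc1ccnc(Cc2cc(Nc3nc(C)cn4c(-c5cn[nH]c5)cnc34)sn2)c1` gives 1850 ng.h/mL. Going by the values given here, this is the only number in the set. Compound 1 `Cc1cn2c(-c3cn[nH]c3)cnc2c(Nc2cc(Cn3cccc3)ns2)n1` gives "not determined" (no result reported) on this read-out. Compound 2 `Cc1cn2c(-c3cn[nH]c3)cnc2c(Nc2cc(Cn3cccc(C)c3=O)ns2)n1` gives "not determined" (no result reported) on this read-out. So compound 3 stands alone as the single measured point with nothing to rank it against. Compound 4 `Cc1cn2c(-c3cn[nH]c3)cnc2c(Nc2cc(Cc3cccc(F)n3)ns2)n1` differs from compound 3 in one place: 6-fluoropyridin-2-yl in place of 4-methylpyridin-2-yl on a saturated chain carbon bound to an aromatic carbon. Among the compounds with values here, because no step between two measured compounds is available, the size of such a change cannot be read from the data. The expected step of a 1.2-fold lower number from compound 3 to compound 4 (0.09 log units; within the scatter) is therefore no larger than the usual scatter, in no fixed direction. The estimate for compound 4 in this assay is 1500 ng.h/mL, with a range from 500 ng.h/mL to 4500 ng.h/mL.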

Compound 4, area under the concentration-time curve: 2970 ng.h/mL
For compound 4 the middle estimate is 2.0-fold (0.30 log units) below the measured one; measured number inside the range.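

In this assay, the swap on a saturated chain carbon bound to an aromatic carbon reads as a 1.6-fold higher number from compound 3 to compound 4 (0.21 log units; within the scatter), the first step available in this set. It shows that, at this place, 6-fluoropyridin-2-yl and 4-methylpyridin-2-yl cannot be told apart on this read-out, while the steps to compound 1 and compound 2 cannot be read. No measurement at hand offers an explanation for this result.

Still open, from the compounds shown here alone, is whether an unsubstituted pyridin-2-yl, a phenyl ring or a saturated amine such as morpholine would fit at this place with similar exposure.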